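The source may hold more compounds than are shown below. What is called first, only, known or untested is meant among the compounds shown, and "the series" means these compounds.

Measured so far:
compound 1 `COC(=O)C(c1ccccc1)n1nnnc1[C@@H](COCc1ccccc1)NC(=O)C(C)(C)N` gives 20 nM
compound 2 `CC(C)(N)C(=O)N[C@H](COCc1ccccc1)c1nnnn1CC#N` gives 29 nM
compound 3 `CC(C)(N)C(=O)N[C@H](COCc1ccccc1)c1nnn(Cc2ccc(NS(C)(=O)=O)cc2)n1` gives 986 nM

In a functional assay on H4 cells for agonist activity at growth hormone secretagogue receptor type 1 (Homo sapiens), read by FLIPR (on this read-out higher numbers stand for an effect only at larger amounts of compound and lower numbers for an effect already at smaller amounts), compound 3 stands highest of the three numbers, well beyond the scatter from both compound 2 and compound 1. Compound 4 `CC(C)(N)C(=O)N[C@H](COCc1ccccc1)c1nnn(C/C=C/c2ccccc2)n1` differs from compound 3 by 2-phenylethenyl in place of 4-(methanesulfonamido)phenyl on a saturated chain carbon bound to an aromatic nitrogen. For the measured compounds named here, the one measured step at that place, a 1.5-fold higher number from compound 1 to compound 2 (0.16 log units; within the scatter), stayed within the scatter, while the values of compound 2 and compound 3 show that the 4-(methanesulfonamido)phenyl group goes with a far higher number. Since compound 4 carries 2-phenylethenyl instead, it is expected to move part of the way back toward the lower numbers, a step of a 6.6-fold lower number from compound 3 to compound 4 (0.82 log units; beyond the scatter). Compound 4 is therefore estimated at 150 nM, in a range from 30 nM to 700 nM.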

Compound 4, half-maximal effective concentration: 517 nM
Beside the measured number, compound 4's estimate is 3.4-fold (0.54 log units) below it; the measured number falls inside the stated range.
By their numbers in this assay, from the lowest: compounds 1 and 2 (each within the scatter of the next); then compounds 4 and 3 (each within the scatter of the next).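

In this assay the change on a saturated chain carbon bound to an aromatic nitrogen gives a 1.9-fold lower number from compound 3 to compound 4 (0.28 log units; within the scatter) and so does not separate these two groups, which both carry a six-membered aromatic ring of carbon only. Giving up the hydrogen-bond donor, the hydrogen-bond acceptors and the sulfur of the leaving group thus leaves the number within the scatter. Nothing shown explains why the two groups read alike.

Going by these compounds, it stays open whether the aromatic ring matters at this place at all, as a plain propyl chain in its stead would show. On these data alone, whether a carboxylic acid or an amine in place of the methanesulfonamido part would read the same also remains open.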